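The source may hold more compounds than are shown below. What is called first, only, known or untested is meant among the compounds shown, and "the series" means these compounds.

Compound 1 `COc1ccccc1COc1ccccc1/C=C/C=C1\SC(=S)NC1=O` gives 78.8% in an assay on isolated protein for inhibition of protein tyrosine phosphatase type IVA 3 (Homo sapiens), tested at 5 ug/mL; on this read-out lower numbers stand for less inhibition and higher numbers for more inhibition at the one concentration tested (going by the name of the read-out).
Compound 2 `O=C1NC(=S)S/C1=C\C=C\c1ccccc1OS(=O)(=O)c1ccccc1` gives 64.2% in this assay.
Compound 3 `O=C1NC(=S)S/C1=C\c1cc(Br)ccc1OCc1ccccc1Br` gives 65.2% in this assay.

Of these three, compound 1 stands highest, and its lead over compound 3 and over compound 2 lies beyond the usual scatter in each case. Compound 4 `O=C1NC(=S)S/C1=C\C=C\c1ccccc1OCc1ccccc1Br` has not yet been measured in this assay. It differs from compound 1 in one place: bromo in place of methoxy on an aromatic carbon. Among the measured compounds shown here, no pair of measured compounds shows this change on its own, so the direction can only be estimated. The step is expected to be a number 8.8 percentage points lower from compound 1 to compound 4 (within the scatter), a change of modest size. Compound 4 is therefore estimated at 70%, with a range from 55% to 85%.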

Compound 4, a percentage reported as inhibition, at one concentration (the size of the read-out at that concentration, not a potency): 63.1%
Estimate against measurement, compound 4: 6.9 percentage points above; the range from low to high includes it.
By their numbers in this assay, from the lowest: compounds 4, 2 and 3 (each within the scatter of the next); then compound 1.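

In this assay, bromo in place of methoxy gives a number 15.7 percentage points lower from compound 1 to compound 4 (beyond the scatter). Among the compounds shown here, this is the first pair that differs in one place only, and it shows that the group on this aromatic carbon, ortho to a large group, can change the read-out by itself. No measurement shown here explains the drop.

The compounds shown leave open how other groups at this place would compare, such as a hydroxyl, an amine or a plain hydrogen. A single pair also cannot tell whether the same change would give a similar step on another core.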